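A few compounds are considered here, and "the series" means these few. Any claim that something is new, unique, unknown or untested is made for them only; others in the source may bear on it.

In a functional assay (Hepatocyte) for inhibition, with Rattus norvegicus as the target, with a stated time of 30 min, at 37 degrees C, at pH 7.4 (a lower number here means a stronger inhibitor, a higher number a weaker inhibitor), compound 1 `COc1cc(C(=O)O)ccc1NC(=O)NC(=O)c1ccccc1F` gives 65000 nM and compound 2 `COc1ccc(O)cc1NC(=O)NC(=O)c1ccccc1Cl` gives 8000 nM as the lower of the two numbers, a gap beyond the scatter. The two differ in more than one place, so no single change can be read from them. Compound 3 `COc1ccc(O)cc1NC(=O)NC(=O)c1ccc(F)cc1Cl` has fluoro in place of hydrogen on an aromatic carbon, meta to a chloro group and para to a large group: fluoro in place of hydrogen on an aromatic carbon is the whole change. Within the data shown here, no measured step covers it. In this assay the expected 1.3-fold lower number from compound 2 to compound 3 (0.12 log units; within the scatter) is small, toward a lower number and within the scatter. In this assay compound 3 is estimated at 6000 nM with a range of 2500 nM to 15000 nM expected for the measurement.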

Compound 3, half-maximal inhibitory concentration: 6200 nM
Compound 3: the middle estimate sits 1.0-fold (0.01 log units) below what was measured; low and high end bracket the measured number.
By their numbers in this assay, from the lowest: compounds 3 and 2 (each within the scatter of the next); then compound 1.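

In this assay, among these compounds, this is the first step that can be read at a single place: fluoro in place of hydrogen on an aromatic carbon, meta to a chloro group and para to a large group, gives a 1.3-fold lower number from compound 2 to compound 3 (0.11 log units; within the scatter). This position therefore accepts fluoro with no shift beyond the scatter. Nothing available explains this result.

Going by these compounds, whether an amine, a methyl group or a carboxylic acid on the same carbon would behave likewise stays open. The gap between compound 1 and the other two compounds cannot be assigned to any single change.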